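Azide for Chloride on a Macrocyclic Enone

A few compounds are considered here, and "the series" means these few. Any claim that something is new, unique, unknown or untested is made for them only; others in the source may bear on it.

Measured compounds:
compound 1, `COC/C1=C/C[C@](C)(CCC=C(C)C)/C=C/[C@@H](OC(=O)C=C(C)C)[C@](C)(OC)/C=C/C1=O`: 14600 nM
compound 2, `CC(C)=CCC[C@]1(C)/C=C/[C@@H](OC(=O)C=C(C)C)[C@](C)(O)/C=C/C(=O)/C(CCl)=C\C1`: 390 nM
compound 3, `CC(C)=CCC[C@]1(C)/C=C/[C@@H](OC(=O)C=C(C)C)[C@](C)(O)CCC(=O)/C(CO)=C\C1`: > 40000 nM

All three were run in a functional assay on SW480 cells (Homo sapiens) for antiproliferative activity, read by MTT assay, with a stated time of 48 h; a lower number here means a stronger inhibitor, a higher number a weaker inhibitor. Compound 3 reached only a limit there, (the limit of > 40000 nM in this assay, at which 1 of the 3 values shown sits), so it gives no number. Among the two numbers that exist, compound 2 stands lowest; the nearer of the two, compound 1, sits far above it, beyond the usual scatter. Compound 2 therefore sets the reference point for the step considered here.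

The unmeasured compound is compound 4, `CC(C)=CCC[C@]1(C)/C=C/[C@@H](OC(=O)C=C(C)C)[C@](C)(O)/C=C/C(=O)/C(CN=[N+]=[N-])=C\C1`. It differs from compound 2 in one place: azido in place of chloro on a saturated chain carbon bound to a double-bonded ring carbon. Among the measured compounds shown here, no measured pair in the set shares this change, so the size of the step cannot be read from the data; the chloromethyl group of compound 2 is the only one of its kind among the three, and the hydroxymethyl compound 3 is not comparable because its enone is also saturated.

The writer expects compound 4 to lose some potency against compound 2, but not to drop to the limit. In this assay compound 4 is estimated at 1500 nM, with a range from 400 nM to 6000 nM. That estimate means a step of a 3.8-fold higher number from compound 2 to compound 4 (0.59 log units; beyond the scatter) toward a weaker inhibitor.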

Compound 4, half-maximal inhibitory concentration: 4230 nM
Estimate against measurement, compound 4: 2.8-fold (0.45 log units) below, and the stated range covers the measured number.
By their numbers in this assay, from the lowest: compound 2; then compound 4; then compound 1. At a limit, above all of these: compound 3.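

Among the compounds shown here, exchanging chloro for azido on this saturated chain carbon bound to a double-bonded ring carbon gives an 11-fold higher number from compound 2 to compound 4 (1.04 log units; beyond the scatter) in this assay, the first direct reading of this position, as no earlier pair differed only here. The step shows that the group at this place strongly affects the antiproliferative read-out, yet the azidomethyl compound 4 still gives a number, 4230 nM, rather than a limit. The compounds shown offer no measured property that would account for the size of this step.

For the compounds shown here, with only this one pair, it remains open whether the higher number reflects something particular to azido or whether chloro is the exception among groups at this place. As far as these compounds go, how a bromomethyl or an aminomethyl group would read on the otherwise unchanged structure of compound 2 also remains open, as does whether the step from chloromethyl to azidomethyl would keep its size on a core with other changes elsewhere.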